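Three chromone acids at the assay limit and a fourth

The source may report more compounds than this note shows. Statements on the series, on what has been measured and on what is new or still open speak of the compounds shown alone.

Compound 1, `COc1cc(-c2oc3ccccc3c(=O)c2C(=O)O)cc(OC)c1OC`: in a functional assay on HT-29 cells (Homo sapiens) for cytotoxicity, read by MTT assay, with a stated time of 6 days (a higher number here means that more compound is needed for the effect, a lower number that less compound is needed), compound 1 gives > 25 ug/mL, which is a limit of the assay and not a number.
Compound 2, `COc1cc(OC)cc(-c2oc3ccccc3c(=O)c2C(=O)O)c1`: in this assay compound 2 gives > 25 ug/mL, again only a limit.
Compound 3, `O=C(O)c1c(-c2ccc([N+](=O)[O-])cc2)oc2ccccc2c1=O`: in this assay compound 3 gives > 25 ug/mL, also a limit.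

Compound 4, `COc1ccc2oc(-c3ccc([N+](=O)[O-])cc3)c(C(=O)O)c(=O)c2c1`, has not yet been measured in this assay. It differs from compound 3 by one change, (methoxy in place of hydrogen on an aromatic carbon). The same kind of change is found among the measured compounds, where compound 1 differs from compound 2 by methoxy in place of hydrogen on an aromatic carbon. The two places are not the same, however: in compound 1 the entering methoxy sits ortho to two methoxy groups and para to a large group, while in compound 4 it sits on a ring that is part of a fused or bridged system of two rings, meta to a fused ring and para to a fused ring. The measured step that the two limits leave unreadable from compound 2 to compound 1 gives no readable size, since both ends are limits. How the core of compound 3 differs from that of compound 2 is not broken down here.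

What can be expected for compound 4 rests on a single observation: because of the limit of > 25 ug/mL in this assay, at which 3 of the 3 values shown sit, there is no sign among these compounds that either methoxy change moves the read-out into the measurable range. Compound 4 is therefore expected to sit at or beyond the same limit, a step that the limit leaves unreadable from compound 3 to compound 4. The estimate for compound 4 in this assay is 30 ug/mL, in a range from 8 ug/mL to 100 ug/mL.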

Compound 4, concentration for half-maximal effect: > 25 ug/mL
Compound 4: a limit, no number (the forecaster's own chance of this, stated with the estimate: 80%); the middle value lies beyond the limit too.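

Compound 3 and compound 4 both sit at a limit of this assay and give no number, so no step can be read between them: the limit of > 25 ug/mL in this assay, at which 4 of the 4 values shown sit.

The compounds shown leave open how far beyond that limit each of the four lies in this assay, and so whether methoxy in place of hydrogen on an aromatic carbon changes the read-out at all.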